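This account rests on a few compounds, and the source may have more. Where it says the series, first, only, none or still open, it means among the compounds named here.

Measured so far in a functional assay on HeLa cells (Homo sapiens) for antiproliferative activity, read by MTT assay, with a stated time of 48 h; on this read-out higher numbers stand for weaker inhibition and lower numbers for stronger inhibition:
compound 1 `Clc1ccc(CSc2nnc(-c3cnccn3)o2)cc1` gives 24600 nM
compound 2 `Brc1ccc(CSc2nnc(-c3cnccn3)o2)cc1` gives 21600 nM
compound 3 `Clc1ccccc1CSc1nnc(-c2cnccn2)n1-c1ccccc1` gives > 50000 nM, which is a limit of the assay and not a number.

Compound 1 and compound 2 differ by bromo in place of chloro on an aromatic carbon; the step is a 1.1-fold lower number from compound 1 to compound 2 (0.06 log units; within the scatter). For compound 3 the assay reports only a limit, (the limit of > 50000 nM in this assay, at which 1 of the 3 values shown sits). The difference between the core of compound 1 and the core of compound 3 is not broken down here.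

Compound 4 `Brc1ccccc1CSc1nnc(-c2cnccn2)n1-c1ccccc1` is not yet measured. It differs from compound 3 by bromo in place of chloro on an aromatic carbon, the same kind of change, though here the place reads ortho to a large group where the earlier one read para to a large group. The expected step is a step that the limit leaves unreadable from compound 3 to compound 4, and this rests on a 1.1-fold lower number from compound 1 to compound 2 (0.06 log units; within the scatter), so a limit is again the likely outcome. For compound 4 the estimate in this assay is 60000 nM, expected to fall between 30000 nM and 130000 nM.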

Compound 4, half-maximal inhibitory concentration: > 50000 nM
Compound 4: only a limit was reported; the forecaster's own chance of this, stated with the estimate: 70%; the middle value does not contradict the limit.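

Compound 3 and compound 4 are both reported only as limits, so no step can be read between them: the limit of > 50000 nM in this assay, at which 2 of the 4 values shown sit.

Still open, as far as these compounds go, is whether bromo in place of chloro matters on this core, and how the core of compound 3 compares with the core of compound 1.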